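The compounds below may be only part of what the source reports. "The series", "measured", "known", "first", "only" and "open" are said of these compounds alone.

Compound 1 `O=C(Nc1cccc(-n2cc(-c3ccncc3)c(-c3ccc(Cl)c(O)c3)n2)c1)Nc1cccc(C(F)(F)F)c1` gives 948 nM in a functional assay on PC-3 cells (Homo sapiens) for inhibition, read by sulforhodamine B assay, with a stated time of 48 h; on this read-out lower numbers stand for stronger inhibition of growth and higher numbers for weaker inhibition of growth.
Compound 2 `COc1cc(-c2nn(-c3cccc(NC(=O)Nc4ccc(Cl)c(Cl)c4)c3)cc2-c2ccncc2)ccc1Cl` gives 554 nM.
Compound 3 `COc1cc(-c2nn(-c3cccc(NC(=O)Nc4cccc(C(F)(F)F)c4)c3)cc2-c2ccncc2)ccc1Cl` gives 372 nM.

Compound 3 carries the lowest of the three numbers; nearest is the step of a 1.5-fold lower number from compound 2 to compound 3 (0.17 log units; within the scatter), furthest the step of a 2.5-fold lower number from compound 1 to compound 3 (0.41 log units; beyond the scatter). Compound 4 `COc1cc(-c2nn(-c3cccc(NC(=O)Nc4ccc(Cl)c(C(F)(F)F)c4)c3)cc2-c2ccncc2)ccc1Cl` differs from compound 3 by chloro in place of hydrogen on an aromatic carbon. Going by the values given here, the one measured step that bears on substituents of this ring is a 1.5-fold lower number from compound 2 to compound 3 (0.17 log units; within the scatter), which stayed within the scatter, so changes here have so far moved little. Compound 4 combines a chloro and a trifluoromethyl on that ring, drawing on the patterns of both compound 2 and compound 3. No step beyond the scatter is therefore expected, a 1.1-fold higher number from compound 3 to compound 4 (0.05 log units; within the scatter). Compound 4 is estimated at 420 nM, range 200 nM to 850 nM.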

Compound 4, concentration for 50% growth inhibition: 690 nM
Beside the measured number, compound 4's estimate is 1.6-fold (0.22 log units) below it; low and high end bracket the measured number.
By their numbers in this assay, from the lowest: compounds 3, 2, 4 and 1 (each within the scatter of the next, the first and the last beyond it).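

Chloro on the 3-(trifluoromethyl)phenyl ring, ortho to the trifluoromethyl group, stays within the scatter in this assay (a 1.9-fold higher number from compound 3 to compound 4 (0.27 log units; within the scatter)). Trifluoromethyl in place of chloro on the same ring also stays within it (a 1.2-fold higher number from compound 2 to compound 4 (0.10 log units; within the scatter)), so the three patterns on this ring in compound 2, compound 3 and compound 4 show no step beyond the scatter among them. Nothing on hand explains these small steps.

Open, as far as these compounds go, is whether an amine or a carboxylic acid on this ring would move the number beyond the scatter. Also open, from the compounds shown here alone, is whether the hydrogen-to-methyl step on the oxygen holds with other groups on this ring.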